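A Larger Sulfur-Containing Group in Place of Benzyl

This account rests on a few compounds, and the source may have more. Where it says the series, first, only, none or still open, it means among the compounds named here.

Of the compounds shown here, three have been measured in a functional assay on the whole organism for inhibition, with Rattus norvegicus as the target; on this read-out higher numbers stand for an effect only at larger amounts of compound and lower numbers for an effect already at smaller amounts. Compound 1 `Cc1ccc(CC(Oc2ccc(C(C)C)cc2)C(=O)O)cc1` is reported only as a limit, < 50 mg/kg. Compound 2 `CC(C)c1ccc(OC(C)(Cc2ccc(C(F)(F)F)cc2)C(=O)O)cc1` is also reported only as a limit, < 5 mg/kg. Among the compounds with values here, compound 3 `CC(Cc1ccc(Cl)cc1)(Oc1ccc(Cc2ccccc2)cc1)C(=O)O` gives 1 mg/kg, the only actual number among the three and so the one firm reference point.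

Compound 4 `CC(Cc1ccc(Cl)cc1)(Oc1ccc(C2CCSc3ccccc32)cc1)C(=O)O` departs from compound 3 in one place: a group of 10 heavy atoms (9 carbon, 1 sulfur; one six-membered non-aromatic ring with 1 hetero atom, one six-membered aromatic ring of carbon only) in place of a group of 7 heavy atoms (7 carbon; one six-membered aromatic ring of carbon only), on an aromatic carbon. Benzyl leaves, and a group with one six-membered non-aromatic ring with 1 hetero atom and one six-membered aromatic ring of carbon only enters. Within the data shown here, no measured pair differs in just one place, so the data offer no direct guide to the size of this step. In this assay, no change beyond the scatter is expected in either direction. Among the measured compounds shown here, that expectation rests on the value of compound 3, 1 mg/kg, and on the six-membered aromatic ring of carbon only that both groups carry. The expected step is no change at the digits printed from compound 3 to compound 4 (within the scatter). For compound 4 the estimate is 1 mg/kg, with an expected range of 0.3 mg/kg to 4 mg/kg.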

Compound 4, dose for half-maximal effect: 10 mg/kg
For compound 4 the middle estimate is 10-fold (1.00 log units) below the measured one; measured number above the stated range.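

Within the data shown here, this is the first step between two measured compounds that differ in one place, and it shows that this aromatic carbon, para to a large group, does not accept every group that carries a six-membered aromatic ring of carbon only. In this assay, putting the sulfur-containing group in place of benzyl gives a 10-fold higher number from compound 3 to compound 4 (1.00 log units; beyond the scatter), so a larger amount of compound is needed for the effect. Nothing in the data at hand accounts for this step.

From the compounds shown here alone, it remains open whether the sulfur atom or the larger ring system carries the change. An oxygen atom in place of that sulfur, or a sulfone at the same spot, would help separate the two, and a simple phenyl group on that aromatic carbon would show how much of the benzyl group is needed.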